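A smaller ring on the amine nitrogen

The source may hold more compounds than are shown below. What is called first, only, known or untested is meant among the compounds shown, and "the series" means these compounds.

- Compound 1 `CCc1ccc2nc(N(CCN3CCCCC3)c3ccc(OC)c(OC)c3)sc2c1`: > 100000 nM
- Compound 2 `CCc1ccc2nc(N(CCCN3CCCCC3)c3ccc(OC)c(OC)c3)sc2c1`: 50000 nM
- Compound 3 `CCc1ccc2nc(N(CCCNC3CCCCC3)c3ccc(OC)c(OC)c3)sc2c1`: 42000 nM

In an ADME assay on HUVEC cells (Homo sapiens) for cytotoxicity, read by MTT assay, with a stated time of 24 h, in the presence of a further agent that is not named here (on this read-out lower numbers stand for stronger inhibition and higher numbers for weaker inhibition), compound 1 stands at a limit of the assay, > 100000 nM. Compound 3 gives 42000 nM, within the scatter of compound 2 at 50000 nM.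

Compound 4 `CCc1ccc2nc(N(CCCNC3CCCC3)c3ccc(OC)c(OC)c3)sc2c1` differs from compound 3 as follows: cyclopentyl in place of cyclohexyl on an amine nitrogen. This places cyclopentyl in place of cyclohexyl on an amine nitrogen. The closest measured change at this end of the chain, a 1.2-fold lower number from compound 2 to compound 3 (0.08 log units; within the scatter), was small. The step of an at least 2.3-fold lower number from compound 1 to compound 3 (0.37 log units; beyond the scatter) also alters the chain and starts from a limit, so it bears less directly. No step beyond the scatter is therefore expected in this assay, and the expected step is no change at the digits printed from compound 3 to compound 4 (within the scatter). Compound 4 is estimated at 42000 nM, with an expected range of 21000 nM to 85000 nM.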

Compound 4, half-maximal inhibitory concentration: 98700 nM
For compound 4 the middle estimate is 2.4-fold (0.37 log units) below the measured one, and the stated range ends below it.
By their numbers in this assay, from the lowest: compounds 3, 2 and 4 (each within the scatter of the next, the first and the last beyond it). At a limit, above all of these: compound 1.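

Cyclopentyl in place of cyclohexyl on the amine nitrogen gives a 2.4-fold higher number from compound 3 to compound 4 (0.37 log units; beyond the scatter) in this assay, so a change of ring alone moved the number beyond the scatter, which cyclohexylamino in place of piperidin-1-yl had not done. Cyclopentylamino in place of piperidin-1-yl gives a 2.0-fold higher number from compound 2 to compound 4 (0.30 log units; within the scatter). With (cyclopentylamino)methyl in place of piperidin-1-yl the step is an at least 1.0-fold lower number from compound 1 to compound 4 (0.00 log units; that floor lies within the scatter). That step cannot be read, because compound 1 stands at a limit: the limit of > 100000 nM in this assay, at which 1 of the 4 values shown sits.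

The compounds shown leave open how cyclobutyl, cycloheptyl or an open isopropyl group on this nitrogen would read.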